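Methoxy in place of ethylamino on the carbonyl carbon

This account rests on a few compounds, and the source may have more. Where it says the series, first, only, none or still open, it means among the compounds named here.

Compound 1 `O=C(O)c1cc2c(Nc3ccc(OC(F)(F)F)cc3)ncnc2s1` in an ADME assay on BaF3 cells (Mus musculus) for cytotoxicity (a lower number here means that less compound is needed, a higher number that more compound is needed for the effect), gives > 10000 nM, a limit of this assay.
Compound 2 `CCNC(=O)c1cc2c(Nc3ccc(OC(F)(F)F)cc3)ncnc2s1` in this assay gives > 10000 nM, likewise a limit.

Compound 2 thus stands at the limit of > 10000 nM in this assay, at which 2 of the 2 values shown sit. Within the data shown here, the one measured step, a step that the two limits leave unreadable from compound 1 to compound 2, has no readable size and cannot point in any direction. Compound 3 `COC(=O)c1cc2c(Nc3ccc(OC(F)(F)F)cc3)ncnc2s1` differs from compound 2 by methoxy in place of ethylamino on a carbonyl carbon. With both neighbours sitting at the limit, no change beyond the scatter is expected in this assay, and compound 3 is expected to stay at the limit as well, which means an estimated step of a number no higher from compound 2 to compound 3 (the limit leaves the size open). The estimate for compound 3 is 10000 nM, within 4000 nM to 30000 nM.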

Compound 3, half-maximal effective concentration: > 10000 nM
Compound 3: no number, only a limit; the forecaster's own chance of this, stated with the estimate: 80%; the middle value sits exactly at the limit.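

In this assay, among these compounds, compound 3 gives > 10000 nM, a limit, and with compound 1 and compound 2 also at limits, no step among the three can be read. The compounds shown leave open whether changing the group on the carbonyl carbon shifts the true values in this assay.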